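The source may hold more compounds than are shown below. What is called first, only, known or untested is meant among the compounds shown, and "the series" means these compounds.

Compound 2, `O=C(NCCCNc1cc(-c2cn(-c3ccccc3)nc2-c2cccc(O)c2)ccn1)c1ccccc1`, gives 5120 nM in a functional assay on HCT-15 cells (Homo sapiens) for inhibition; on this read-out lower numbers stand for stronger inhibition of growth and higher numbers for weaker inhibition of growth. That is the lowest of the two numbers recorded so far, though the standing carries little weight: its nearest neighbour, compound 1, `COc1cccc(-c2nn(-c3ccccc3)cc2-c2ccnc(NCCCNC(=O)Nc3ccc(Cl)c(Cl)c3)c2)c1`, gives 6660 nM in this assay, and the gap between the two lies within the scatter, so neither compound can be called the more potent. Compound 3, `O=C(NCCCNc1cc(-c2cn(-c3ccccc3)nc2-c2cccc(O)c2)ccn1)c1ccc(F)cc1`, is the next compound to be measured. It differs from compound 2 in a single place: fluoro in place of hydrogen on an aromatic carbon. Among the compounds with values here, no step between measured compounds bears on a change of this kind, and nothing among the numbers so far points one way or the other. The step of a 1.1-fold lower number from compound 2 to compound 3 (0.06 log units; within the scatter) is expected to stay within the scatter, with no direction that can be stated with confidence. Compound 3 is therefore estimated at 4500 nM, with a range from 2000 nM to 10000 nM.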

Compound 3, concentration for total growth inhibition: 3710 nM
Beside the measured number, compound 3's estimate is 1.2-fold (0.08 log units) above it; the measured number falls inside the stated range.
By their numbers in this assay, from the lowest: compounds 3, 2 and 1 (each within the scatter of the next).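

In this assay, putting fluoro in place of hydrogen on an aromatic carbon, para to a large group, gives a 1.4-fold lower number from compound 2 to compound 3 (0.14 log units; within the scatter). Within the data shown here, this is the first comparison in which only one place differs, and it shows that turning the benzoyl into (4-fluorophenyl)carbonyl leaves the number within the scatter, so this single change gives no measurable gain or loss here. Nothing available speaks to a cause for this result.

The compounds shown leave open whether chloro, methoxy or an amine on the same aromatic carbon would carry the number beyond the scatter. They also leave open whether a longer chain linking the amide to the shared core would do so.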